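A swap on the aromatic nitrogen, awaiting compound 3

The source may report more compounds than this note shows. Statements on the series, on what has been measured and on what is new or still open speak of the compounds shown alone.

Measured so far in a functional assay on MCF7 cells (Homo sapiens) for inhibition, read by MTT assay, with a stated time of 72 h; on this read-out higher numbers stand for weaker inhibition and lower numbers for stronger inhibition:
Compound 1 `Cc1cc2occ(-c3nc(-c4ccccc4)c(-c4ccccc4)n3-c3ccccc3Cl)c(=O)c2cc1Cl` gives 3120 nM
Compound 2 `Cc1cc2occ(-c3nc(-c4ccccc4)c(-c4ccccc4)n3-c3cccc([N+](=O)[O-])c3)c(=O)c2cc1Cl` gives 1560 nM

Going by the values given here, compound 2 stands level with compound 1, the only other compound measured. The step between them is a 2.0-fold lower number from compound 1 to compound 2 (0.30 log units; within the scatter), so the two numbers cannot be told apart. Among the compounds with values here, that step, 3-nitrophenyl in place of 2-chlorophenyl on an aromatic nitrogen, is also the only measured evidence for what comes next.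

Compound 3 `Cc1cc2occ(-c3nc(-c4ccccc4)c(-c4ccccc4)n3-c3ccc(Br)cc3)c(=O)c2cc1Cl` keeps the shared core and changes the same place: 4-bromophenyl in place of 3-nitrophenyl on an aromatic nitrogen. In words, 4-bromophenyl replaces 3-nitrophenyl on an aromatic nitrogen. Within the data shown here, no measured compound carries 4-bromophenyl, and the data give no firm direction for this change. Among the measured compounds shown here, the single swap at this nitrogen, a 2.0-fold lower number from compound 1 to compound 2 (0.30 log units; within the scatter), did not move the number beyond the scatter, and no larger move is expected here in this assay. For the measured compounds named here, the expected change is a 1.4-fold higher number from compound 2 to compound 3 (0.15 log units; within the scatter), which amounts to an estimate of no real step. Compound 3 is expected at 2200 nM, with an estimated range from 750 nM to 6500 nM.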

Compound 3, half-maximal inhibitory concentration: 1560 nM
Estimate against measurement, compound 3: 1.4-fold (0.15 log units) above; measured number inside the range.
By their numbers in this assay, from the lowest: compounds 2, 3 and 1 (each within the scatter of the next).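

In this assay, 4-bromophenyl in place of 3-nitrophenyl on the aromatic nitrogen gives no change at the digits printed from compound 2 to compound 3 (within the scatter) and 4-bromophenyl in place of 2-chlorophenyl gives a 2.0-fold lower number from compound 1 to compound 3 (0.30 log units; within the scatter) on the same read-out. Going by these compounds alone, the single swap seen before has become a set of three differently substituted phenyl groups at this nitrogen, and no step among them stands beyond the scatter, even though 4-bromophenyl has no hydrogen-bond acceptors and 3-nitrophenyl does. Nothing shown accounts for this flat result, and no supporting measurement bears on it.

On these data alone, all three compounds keep a substituted phenyl ring on this nitrogen, so it remains open whether a plain phenyl, a benzyl group, a short alkyl chain, or a phenyl ring bearing an amine or a carboxylic acid would move the number beyond the scatter. As far as these compounds go, the two phenyl groups on the five-membered ring and the rest of the shared core are the same throughout, so what a change at those places would do also stays open.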